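The compounds below may be only part of what the source reports. "The series", "measured", "known", "first", "only" and "open" are said of these compounds alone.

The measured compounds:
Compound 1 `Nc1cccc2c(-c3cccc(NC(=O)c4nccs4)c3)ccnc12` gives 16700 nM in a functional assay on A375P cells (Homo sapiens) for antiproliferative activity, read by MTT assay, with a stated time of 48 h; a lower number here means a stronger inhibitor, a higher number a weaker inhibitor.
Compound 2 `Nc1cccc2c(-c3cccc(NC(=O)c4cc5ccccc5s4)c3)ccnc12` gives > 20000 nM in this assay, which is a limit of the assay rather than a number.
Compound 3 `CC(=O)Nc1cccc2c(-c3cccc(NC(=O)c4nccs4)c3)ccnc12` gives > 20000 nM in this assay, again a limit rather than a number.

Compound 1 is the only one of the three with a numerical value, and it is already a weak inhibitor. Two separate changes are made from it. Compound 2 differs from compound 1 by 1-benzothiophen-2-yl in place of 1,3-thiazol-2-yl on a carbonyl carbon, and the step is an at least 1.1-fold higher number from compound 1 to compound 2 (0.07 log units; that floor lies within the scatter). Compound 3 differs from compound 1 by acetyl in place of hydrogen on a nitrogen on an aromatic ring, and the step is an at least 1.1-fold higher number from compound 1 to compound 3 (0.07 log units; that floor lies within the scatter). Neither step can be sized properly because of the limit of > 20000 nM in this assay, at which 2 of the 3 values shown sit, so both are known only as floors.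

Compound 4 `CC(=O)Nc1cccc2c(-c3cccc(NC(=O)c4cc5ccccc5s4)c3)ccnc12` has not yet been measured in this assay. It differs from compound 3 by 1-benzothiophen-2-yl in place of 1,3-thiazol-2-yl on a carbonyl carbon. This is the same change that turns compound 1 into compound 2, made at the same kind of place, on the carbonyl carbon next to the amide-type nitrogen in both cases.

Because compound 3 already sits at the limit > 20000 nM, and because the same change once before produced an at least 1.1-fold higher number from compound 1 to compound 2 (0.07 log units; that floor lies within the scatter), compound 4 is expected to remain at or beyond that limit. The step from compound 3 to compound 4 is estimated as a step that the limit leaves unreadable from compound 3 to compound 4. Compound 4 is expected to give about 35000 nM, most likely reported only as a limit, with a plausible range from 15000 nM to 100000 nM.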

Compound 4, half-maximal inhibitory concentration: 9100 nM
Estimate against measurement, compound 4: 3.8-fold (0.59 log units) above; measured number below the stated range.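

In this assay, 1-benzothiophen-2-yl in place of 1,3-thiazol-2-yl on the carbonyl carbon gives an at least 2.1-fold lower number from compound 3 to compound 4 (0.34 log units; beyond the scatter), and acetyl in place of hydrogen on the nitrogen on the aromatic ring gives an at least 2.1-fold lower number from compound 2 to compound 4 (0.34 log units; beyond the scatter), so each change lowers the number when the other is already present. Set beside the earlier step on the core of compound 1, the ring change does not show whether its effect carries from one core to the other, or whether it fails to: the same change on two cores in this assay, an at least 1.1-fold higher number (0.07 log units; that floor lies within the scatter) from compound 1 to compound 2 and an at least 2.1-fold lower number (0.34 log units; beyond the scatter) from compound 3 to compound 4; the limit leaves it open whether they differ The acetyl change stands in the same position, so no rule for either change can be drawn from these four compounds: the same change on two cores in this assay, an at least 1.1-fold higher number (0.07 log units; that floor lies within the scatter) from compound 1 to compound 3 and an at least 2.1-fold lower number (0.34 log units; beyond the scatter) from compound 2 to compound 4; the limit leaves it open whether they differ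

As far as these compounds go, the true size of every step here stays unreadable, because the values of compound 2 and compound 3 are limits of the assay and not numbers: the limit of > 20000 nM in this assay, at which 2 of the 4 values shown sit. Also open is whether the same lowering would appear with other groups, such as a plain phenyl ring on the carbonyl carbon, or a longer chain such as propanoyl in place of acetyl on the nitrogen.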